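A few compounds are considered here, and "the series" means these few. Any claim that something is new, unique, unknown or untested is made for them only; others in the source may bear on it.

- Compound 1 `Cc1ccc(C#Cc2nc(C(N)=O)nn2COCCO)cc1`: > 50 ug/mL
- Compound 2 `NC(=O)c1nc(C#Cc2ccccc2F)n(COCCO)n1`: > 50 ug/mL

In an ADME assay on Huh-5-2 cells (Homo sapiens) for cytotoxicity (on this read-out higher numbers stand for lower toxicity in this test and lower numbers for higher toxicity in this test), compound 2 gives > 50 ug/mL. This is a limit of the assay, not a number. Compound 1 gives > 50 ug/mL, which is also a limit. For the measured compounds named here, compound 2 therefore stands with the only other measured compound: the limit of > 50 ug/mL in this assay, at which 2 of the 2 values shown sit.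

Compound 3 `NC(=O)c1nc(C#CC2=CCCCC2)n(COCCO)n1` keeps the shared core and makes one change: cyclohex-1-en-1-yl in place of 2-fluorophenyl on a triple-bonded carbon. Cyclohex-1-en-1-yl takes the place of 2-fluorophenyl on a triple-bonded carbon. Going by the values given here, the one measured step that bears on this changes the same place: a step that the two limits leave unreadable from compound 1 to compound 2. It offers no readable size. With compound 2 at > 50 ug/mL, no step beyond the usual scatter is expected in this assay, and no direction can be favoured. The expected step is a number no higher from compound 2 to compound 3 (the limit leaves the size open). The assay may well again report only a limit. For compound 3, the estimated value is 50 ug/mL, with an expected range from 20 ug/mL to 100 ug/mL.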

Compound 3, half-maximal cytotoxic concentration: > 50 ug/mL
Compound 3: no number, only a limit (the forecaster's own chance of this, stated with the estimate: 70%); the middle value lies on the limit itself.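

For the compounds shown here, compound 1, compound 2 and compound 3 each give only a limit in this assay, so no step among them can be read: the limit of > 50 ug/mL in this assay, at which 3 of the 3 values shown sit. The compounds shown leave open how the three actually compare in cytotoxicity, and whether changing the group on the triple-bonded carbon alters it at all.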